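A few compounds are considered here, and "the series" means these few. Any claim that something is new, unique, unknown or untested is made for them only; others in the source may bear on it.

Compound 1 `Cc1ccc(-c2nn(-c3ccccc3)cc2-c2nc3ccccc3[nH]2)cc1` carries a hydrogen on an aromatic nitrogen, and in a functional assay on A549 cells (Homo sapiens) for antiproliferative activity, read by MTT assay, with a stated time of 24 h (on this read-out lower numbers stand for stronger inhibition and higher numbers for weaker inhibition), compound 1 gives 4010 nM. Two relatives replace that hydrogen with a sulfonyl group. Compound 2 `Cc1ccc(-c2nn(-c3ccccc3)cc2-c2nc3ccccc3n2S(=O)(=O)c2ccc(C)cc2)cc1`, bearing (4-methylphenyl)sulfonyl, gives 460 nM, and the change is an 8.7-fold lower number from compound 1 to compound 2 (0.94 log units; beyond the scatter). Compound 3 `Cc1ccc(-c2nn(-c3ccccc3)cc2-c2nc3ccccc3n2S(=O)(=O)c2ccc(F)cc2)cc1`, bearing (4-fluorophenyl)sulfonyl, gives 3240 nM, and the change is a 1.2-fold lower number from compound 1 to compound 3 (0.09 log units; within the scatter). Compound 3 therefore stands level with compound 1 and well above compound 2, at the weaker end of this small set.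

Compound 4 `Cc1ccc(-c2nn(-c3ccccc3)cc2-c2nc3ccccc3n2S(=O)(=O)c2ccc(Cl)cc2)cc1` alters compound 3 at one place: chloro in place of fluoro on an aromatic carbon, with chloro in place of fluoro on an aromatic carbon, para to a large group. Going by the values given here, the only measured swap at that place is a 7.0-fold higher number from compound 2 to compound 3 (0.85 log units; beyond the scatter), which shows that the group there can shift the number in this assay. Among the compounds with values here, no chloro compound has been measured, so this single step gives a scale and not a firm direction. A landing between the values of the two sulfonyl compounds seems most likely, nearer to compound 3. The expected change is small to modest, toward a lower number: a 2.2-fold lower number from compound 3 to compound 4 (0.33 log units; beyond the scatter). For compound 4 the estimated value is 1500 nM, with an expected range from 500 nM to 4500 nM.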

Compound 4, half-maximal inhibitory concentration: 3550 nM
Beside the measured number, compound 4's estimate is 2.4-fold (0.37 log units) below it; the measured number falls inside the stated range.
By their numbers in this assay, from the lowest: compound 2; then compounds 3, 4 and 1 (each within the scatter of the next).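

In this assay, chloro and fluoro at this place on the aromatic ring cannot be told apart (a 1.1-fold higher number from compound 3 to compound 4 (0.04 log units; within the scatter)), so the earlier fluoro result was not a quirk of one halogen. The chloro compound also sits level with the parent that carries only hydrogen on the aromatic nitrogen (a 1.1-fold lower number from compound 1 to compound 4 (0.05 log units; within the scatter)), which means that compounds 3 and 4 both go against any idea that adding a sulfonyl group lowers the number by itself. Compound 2 now stands apart from a second compound (a 7.7-fold higher number from compound 2 to compound 4 (0.89 log units; beyond the scatter)), so among these three sulfonyl compounds the lower number appears only with methyl, and nothing measured here explains why methyl parts from fluoro and chloro.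

These compounds leave open whether methyl is unusual at this place or whether other groups, such as ethyl, methoxy or an amine, would give a similarly low number. Going by these compounds, it also remains open how a sulfonyl group with a plain phenyl ring, carrying hydrogen at this place, would compare with compound 1 and compound 2.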